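Triazole substituent swap on a shared lactone core

The source may hold more compounds than are shown below. What is called first, only, known or untested is meant among the compounds shown, and "the series" means these compounds.

Measured so far:
- compound 1 `O=C1O[C@H]([C@@H](O)Cn2cc(-c3cccc(O)c3)nn2)C(OCc2ccccc2)=C1OCc1ccccc1`: 54100 nM
- compound 2 `CC(C)(C)OC(=O)N1CCN(C(=S)SCc2cn(C[C@H](O)[C@H]3OC(=O)C(OCc4ccccc4)=C3OCc3ccccc3)nn2)CC1`: > 100000 nM

Among the compounds with values here, in a functional assay on CFPAC-1 cells (Homo sapiens) for antiproliferative activity, read by MTT assay, with a stated time of 72 h (a higher number here means a weaker inhibitor, a lower number a stronger inhibitor), compound 1 gives 54100 nM and is the only compound of the series with a numerical value. For compound 2 the entry > 100000 nM is a limit of the assay and not a number; it marks (the limit of > 100000 nM in this assay, at which 1 of the 2 values shown sits). Within the data shown here, nothing links compound 1 and compound 2 by a single change, so no measured step exists and the two values show only that both sit at the weak end of this assay.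

Compound 3 `C[Si](C)(C)c1cn(C[C@H](O)[C@H]2OC(=O)C(OCc3ccccc3)=C2OCc2ccccc2)nn1` has not yet been measured. It differs from compound 1 at one place: a group of 4 heavy atoms (3 carbon, 1 silicon; no ring) in place of a group of 7 heavy atoms (6 carbon, 1 oxygen; one six-membered aromatic ring of carbon only), on an aromatic carbon.

Among the measured compounds shown here, no measured step is available to calibrate this kind of change. Given that compound 1 already stands at 54100 nM, the step from compound 1 to compound 3 is expected to be a weakening of about a 1.5-fold higher number from compound 1 to compound 3 (0.17 log units; within the scatter), of a size that may not exceed the usual scatter. For compound 3 the expected value in this assay is 80000 nM, within a range from 30000 nM to 250000 nM.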

Compound 3, half-maximal inhibitory concentration: 52600 nM
Beside the measured number, compound 3's estimate is 1.5-fold (0.18 log units) above it, and the stated range covers the measured number.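

In this assay, within the data shown here, replacing 3-hydroxyphenyl with the group of 4 heavy atoms (3 carbon, 1 silicon) on this aromatic carbon gives a 1.0-fold lower number from compound 1 to compound 3 (0.01 log units; within the scatter), the first measured step at this position. The change removes the six-membered aromatic ring, the hydrogen-bond donor and the hydrogen-bond acceptor of the leaving group, yet the two values remain within the scatter of each other, so neither the ring nor the hydroxyl is needed to hold activity at this weak level, and compound 3 gives 52600 nM. No measured property bears on this step, so the values give no account of it.

Still open, on these data alone, is whether an amine, a carboxylic acid or a longer alkyl chain on this same aromatic carbon would give a step beyond the scatter, or whether this position tolerates such groups with as little difference. A plain phenyl group or a methoxyphenyl group here would also separate the contribution of the aromatic ring from that of its hydroxyl, which this single step cannot do.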